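The source may report more compounds than this note shows. Statements on the series, on what has been measured and on what is new or still open speak of the compounds shown alone.

Measured in an ADME assay on HOS cells (Homo sapiens) for cytotoxicity; on this read-out higher numbers stand for lower toxicity in this test and lower numbers for higher toxicity in this test:
- Compound 1 `CN(Cc1nc2ccccc2n1CCCNC(=N)N)C1CCCc2cccnc21`: > 20000 nM
- Compound 2 `CN(Cc1nc2cccc(C(=O)NCCCCN)c2[nH]1)C1CCCc2cccnc21`: > 20000 nM
- Compound 3 `CN(Cc1nc2cccc(CN)c2[nH]1)C1CCCc2cccnc21`: > 20000 nM

Compound 3 stands at > 20000 nM, which is a limit of the assay and not a number. The same is true of the other two entries, so the whole record so far is the limit of > 20000 nM in this assay, at which 3 of the 3 values shown sit.

The next compound is compound 4 `CN(Cc1nc2cccc(CCCN)c2[nH]1)C1CCCc2cccnc21`, and its change is 2-aminoethyl in place of amino on a saturated chain carbon bound to an aromatic carbon. Read one bond further out, aminomethyl gives way to 3-aminopropyl, so the side chain with its terminal amino group grows longer.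

For the measured compounds named here, the only measured step that bears on this is a step that the two limits leave unreadable from compound 2 to compound 3. Going by the values given here, it gives no size to carry over, yet every compound tested so far sits at the limit, whichever side chain it carries. No step beyond the usual scatter is therefore expected in this assay, and another limit is the likeliest report. The expected change is a number no higher from compound 3 to compound 4 (the limit leaves the size open). For compound 4 the estimated value is 20000 nM, with an expected range of 10000 nM to 40000 nM.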

Compound 4, half-maximal cytotoxic concentration: 10000 nM
Estimate against measurement, compound 4: 2.0-fold (0.30 log units) above; low and high end bracket the measured number.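

In this assay, for the compounds shown here, compound 4 gives 10000 nM, the first real number. Every earlier entry is only a limit of the assay. Replacing the aminomethyl group with 3-aminopropyl at this position gives an at least 2.0-fold lower number from compound 3 to compound 4 (0.30 log units; that floor lies within the scatter), so a longer chain ending in an amino group can be linked to a measurable cytotoxic concentration, although this smallest possible step is not beyond normal repeat variation. Replacing (4-aminobutyl)carbamoyl with 3-aminopropyl gives an at least 2.0-fold lower number from compound 2 to compound 4 (0.30 log units; that floor lies within the scatter), and this step carries the same caution.

Going by these compounds, the true size of both steps stays open, since each starts from a limit. On these data alone, it is also open how a longer 5-aminopentyl chain, or a carboxylic acid in place of the terminal amine, would read in this assay.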